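Benzoyl for Phenyl: Solubility Outlook for Compound 4

A few compounds are considered here, and "the series" means these few. Any claim that something is new, unique, unknown or untested is made for them only; others in the source may bear on it.

Measured compounds:
compound 1 `Cc1nccn1-c1cnc(NCc2c(F)ccc3c2CCO3)c2cn[nH]c(=O)c12`: 7000 nM
compound 2 `CN(c1ccccc1)c1cnc(NCc2c(F)ccc3c2CCO3)n2cnnc12`: < 2000 nM, a limit of the assay
compound 3 `CN(C)Cc1ccc2c(c1)CN(c1cnc(NCc3c(F)ccc4c3CCO4)c3cn[nH]c(=O)c13)C2=O`: 174000 nM

All three were read in a physicochemical assay for solubility, read by LC-MS, in phosphate buffer, with a stated time of 24 h, at pH 7.4; a lower number here means a less soluble compound, a higher number a more soluble compound. Compound 1 gives 7000 nM. Compound 3 gives 174000 nM. For compound 2 the result is not a number but a limit of the assay, < 2000 nM. Compound 2 therefore stands at the limit of < 2000 nM in this assay, at which 1 of the 3 values shown sits, so its true solubility is known only as a bound, and no step between it and either of the other two compounds can be sized from what is shown.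

Compound 4 `CN(C(=O)c1ccccc1)c1cnc(NCc2c(F)ccc3c2CCO3)n2cnnc12` is the next compound in this series. It differs from compound 2 in one place: benzoyl in place of phenyl on a nitrogen on an aromatic ring. With compound 2 known only as a limit, the step of an at least 2.0-fold higher number from compound 2 to compound 4 (0.30 log units; that floor lies within the scatter) is expected to be small and in the direction of higher solubility, though it may well fall within the usual scatter. Compound 4 is estimated to give 4000 nM in this assay, with a range from 1500 nM to 15000 nM.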

Compound 4, solubility: 280000 nM
Compound 4: the middle estimate sits 70-fold (1.85 log units) below what was measured; measured number outside the range, above it.
By their numbers in this assay, from the lowest: compound 1; then compounds 3 and 4 (each within the scatter of the next). At a limit, below all of these: compound 2.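

In this assay, benzoyl in place of phenyl on a nitrogen on an aromatic ring comes with an at least 140-fold higher number from compound 2 to compound 4 (2.14 log units; beyond the scatter), a large step and the first that can be sized in this series. For the compounds shown here, until now no two compounds differed in one place, and the earlier values gave no measure of how far a single change could move the read-out. The printed size is a floor rather than a full distance, because compound 2 stands at a limit of the assay: the limit of < 2000 nM in this assay, at which 1 of the 4 values shown sits.

The compounds shown leave open how an acetyl group or a benzyl group on that nitrogen would read in this assay, which would separate the carbonyl from the ring. They also leave open how the benzoyl would read with an amine or a carboxylic acid on its ring.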